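Benzyl on the Ring Nitrogen of Compound 3

The source may hold more compounds than are shown below. What is called first, only, known or untested is meant among the compounds shown, and "the series" means these compounds.

Of the compounds shown here, three have been measured in an assay on cells for inhibition of Polyunsaturated fatty acid 5-lipoxygenase (Rattus norvegicus), tested at 5 uM; on this read-out lower numbers stand for less inhibition and higher numbers for more inhibition at the one concentration tested (going by the name of the read-out). Compound 1 `COc1ccc2c(c1)c(CCCC(=O)N1CCOCC1)c(C)n2Cc1ccc(C)cc1` gives 26.4%, and compound 2 `CC(C)(C)OC(=O)N1CCN(C(=O)CCCc2cn(Cc3ccccc3)c3ccccc23)CC1` gives 38.2%. Compound 3 `COC1(c2cc(F)cc(OCCc3c[nH]c4ccccc34)c2)CCOCC1` stands highest of the three with 64.2%; its nearest neighbour is compound 2, a number that lies beyond the scatter below it, and the furthest is compound 1, lower still. Going by the values given here, no pair of these measured compounds differs in only one place, so the numbers of compounds 1 and 2 show only where they stand, not what any single change is worth.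

The step now followed leads from compound 3 to compound 4 `COC1(c2cc(F)cc(OCCc3cn(Cc4ccccc4)c4ccccc34)c2)CCOCC1`. The difference is benzyl in place of hydrogen on an aromatic nitrogen, on an aromatic nitrogen of a five-membered aromatic ring with 1 nitrogen, part of a fused system of two rings.

Among the compounds with values here, no measured step speaks to this change directly. Compounds 1 and 2, which both carry a group on that aromatic nitrogen, sit well below compound 3, though their cores differ in other places as well. A moderate fall in this assay, a number 14.2 percentage points lower from compound 3 to compound 4 (beyond the scatter), is therefore expected for compound 4, with a value estimated at 50%, between 28% and 72%.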

Compound 4, a percentage reported as inhibition, at one concentration (the size of the read-out at that concentration, not a potency): 31.8%
Beside the measured number, compound 4's estimate is 18.2 percentage points above it, within the range that was stated.
By their numbers in this assay, from the lowest: compounds 1, 4 and 2 (each within the scatter of the next, the first and the last beyond it); then compound 3.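

Going by these compounds alone, the step gives the first direct reading at this position: on the shared core, benzyl in place of hydrogen on an aromatic nitrogen gives a number 32.4 percentage points lower from compound 3 to compound 4 (beyond the scatter) in this assay. Compounds 1 and 2 also carry a benzyl-type group on an aromatic nitrogen, but they differ from compound 3 in other places too and could not isolate this change, whereas this pair differs in that one place alone. The compounds shown give no measured reason for the size of this fall.

From the compounds shown here alone, only hydrogen and benzyl are compared at this position, so it remains open whether a smaller group such as methyl, or a chain ending in an amine or a carboxylic acid, would keep the higher number of compound 3 or share the lower number of compound 4. It also remains open whether the same change is worth as much on the cores of compounds 1 and 2, neither of which has a partner with hydrogen on that nitrogen among the compounds shown.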